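The compounds below may be only part of what the source reports. "The series", "measured", "known", "first", "only" and "open" are said of these compounds alone.

Working notes on the thiosemicarbazone series sharing the core of compound 1.

Of the compounds shown here, three are measured so far. Compound 1 `CC1=CC[C@H](C(C)(C)NC(=S)N/N=C/c2ccc(F)cc2)CC1` reaches only a limit in a functional assay on U-251 cells (Homo sapiens) for inhibition, read by sulforhodamine B assay, with a stated time of 48 h (a lower number here means a stronger inhibitor of growth, a higher number a weaker inhibitor of growth), where compound 1 gives > 100000 nM, a limit rather than a number (the limit of > 100000 nM in this assay, at which 1 of the 3 values shown sits). Compound 2 `CC1=CC[C@H](C(C)(C)NC(=S)N/N=C/c2ccccc2Cl)CC1` gives 80600 nM in this assay. Compound 3 `CC1=CC[C@H](C(C)(C)NC(=S)N/N=C/c2ccc(Cl)cc2)CC1` gives 69500 nM in this assay, the lowest of the two numbers, with compound 2 nearest at a gap within the scatter. The steps seen are an at least 1.2-fold lower number from compound 1 to compound 2 (0.09 log units; that floor lies within the scatter), an at least 1.4-fold lower number from compound 1 to compound 3 (0.15 log units; that floor lies within the scatter) and a 1.2-fold lower number from compound 2 to compound 3 (0.06 log units; within the scatter); none of them rises beyond the scatter.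

Compound 4 `CC1=CC[C@H](C(C)(C)NC(=S)N/N=C/c2ccco2)CC1` is not yet measured. Relative to compound 3 it carries furan-2-yl in place of 4-chlorophenyl on a carbon with a double bond to nitrogen. For the measured compounds named here, none of the measured steps covers an exchange of the aryl ring for a furan; all three concern substituted phenyl rings and were small. No guide therefore exists for a step in either direction, and compound 4 is expected to stay near compound 3, with a step of a 1.3-fold higher number from compound 3 to compound 4 (0.11 log units; within the scatter) estimated. Compound 4 is expected to give about 90000 nM, between 35000 nM and 250000 nM, in this assay.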

Compound 4, concentration for 50% growth inhibition: 9700 nM
Compound 4: middle estimate off by 9.3-fold (0.97 log units), on the high side; measured number below the stated range.
By their numbers in this assay, from the lowest: compound 4; then compounds 3 and 2 (each within the scatter of the next). At a limit, above all of these: compound 1.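

The ring on the carbon with a double bond to nitrogen matters in this assay after all: furan-2-yl gives a 7.2-fold lower number from compound 3 to compound 4 (0.86 log units; beyond the scatter) and an 8.3-fold lower number from compound 2 to compound 4 (0.92 log units; beyond the scatter), whereas the steps among the phenyl compounds stayed within the scatter or, where a limit is involved, had floors within it. For the compounds shown here, compound 4 is thus the strongest inhibitor of growth of the four, and the first clear change comes from exchanging the ring itself, not its halogen. The step of an at least 10-fold lower number from compound 1 to compound 4 (1.01 log units; beyond the scatter) is only a floor, because compound 1 is a limit rather than a number: the limit of > 100000 nM in this assay, at which 1 of the 4 values shown sits.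

The exchange changes ring size, hetero atom and hydrogen-bond acceptor count at once, so these compounds cannot separate the three. On these data alone, whether thiophen-2-yl, pyridin-2-yl or a methyl group on the furan ring would hold the lower number remains open.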